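Aryl swap on the anilino nitrogen of a weak series

The source may report more compounds than this note shows. Statements on the series, on what has been measured and on what is new or still open speak of the compounds shown alone.

Compound 1 `Cc1ccc(Nc2ncc(C(F)(F)F)c(N3Cc4cccc(N(C)S(C)(=O)=O)c4C3)n2)cc1C` gives only a limit of the assay in a functional assay on A549 cells (Homo sapiens) for antiproliferative activity, read by spectrophotometry, with a stated time of 2 days (on this read-out higher numbers stand for weaker inhibition of growth and lower numbers for stronger inhibition of growth), > 30000 nM. Compound 2 `COc1ccc(C(F)(F)F)cc1Nc1ncc(C(F)(F)F)c(N2Cc3cccc(N(C)S(C)(=O)=O)c3C2)n1` likewise gives only a limit, > 30000 nM. Compound 3 `COc1cc(Nc2ncc(C(F)(F)F)c(N3Cc4cccc(N(C)S(C)(=O)=O)c4C3)n2)c(OC)cc1Cl` gives 7300 nM in this assay. Compound 1 thus stands at the weak end of the three, where two of the three values sit (the limit of > 30000 nM in this assay, at which 2 of the 3 values shown sit). Compound 4 `CN(c1cccc2c1CN(c1nc(Nc3ccc(Cl)c(C(F)(F)F)c3)ncc1C(F)(F)F)C2)S(C)(=O)=O` differs from compound 1 by 4-chloro-3-(trifluoromethyl)phenyl in place of 3,4-dimethylphenyl on a nitrogen on an aromatic ring. Among the measured compounds shown here, two measured steps bear on this change: an at least 4.1-fold lower number from compound 1 to compound 3 (0.61 log units; beyond the scatter), while a step that the two limits leave unreadable from compound 1 to compound 2. Compound 4 carries chloro and trifluoromethyl but no methoxy, so a smaller gain than compound 3 showed is expected, and compound 4 may again sit at the limit. The expected step is an at least 1.5-fold lower number from compound 1 to compound 4 (0.17 log units; that floor lies within the scatter). Compound 4 is estimated at 20000 nM, between 6000 nM and 60000 nM.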

Compound 4, concentration for 50% growth inhibition: 15200 nM
The estimate for compound 4 lay 1.3-fold (0.12 log units) above the measured number; measured number inside the range.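

In this assay, 4-chloro-3-(trifluoromethyl)phenyl is a second aryl group on this nitrogen to give a readable number, so a readable number here does not depend on a methoxy group, although the floors of an at least 1.9-fold lower number from compound 1 to compound 4 (0.29 log units; that floor lies within the scatter) and an at least 1.9-fold lower number from compound 2 to compound 4 (0.29 log units; that floor lies within the scatter) are small. Methoxy alone does not suffice either: compound 2 carries one and gives only a limit, > 30000 nM. The swap from the dimethoxy aryl group still costs potency, with a 2.1-fold higher number from compound 3 to compound 4 (0.32 log units; beyond the scatter).

From the compounds shown here alone, whether an amine or a carboxylic acid on this aryl ring would lower the number remains open.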